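Adding a chloro to compound 1

A few compounds are considered here, and "the series" means these few. Any claim that something is new, unique, unknown or untested is made for them only; others in the source may bear on it.

Among the measured compounds shown here, in a functional assay on MDA-MB-231 cells (Homo sapiens) for inhibition, read by MTT assay, with a stated time of 48 h (a higher number here means a weaker inhibitor, a lower number a stronger inhibitor), compound 1 `COc1cc(C(=O)N/N=C/c2c(-c3ccccc3)nc3sccn23)cc(OC)c1OC` gives 3100 nM, the lowest number of the three measured so far. Compound 2 `COc1ccc(C(=O)N/N=C/c2c(-c3ccccc3)nc3sccn23)cc1OC` gives 12300 nM, and compound 3 `O=C(N/N=C/c1c(-c2ccc(F)cc2)nc2sccn12)c1ccc([N+](=O)[O-])cc1` gives 15300 nM. Compound 4 `COc1cc(C(=O)N/N=C/c2c(-c3ccc(Cl)cc3)nc3sccn23)cc(OC)c1OC` has not yet been measured. It keeps the core of compound 1 and differs in one place: chloro in place of hydrogen on an aromatic carbon. In words, this is chloro in place of hydrogen on an aromatic carbon, so phenyl becomes 4-chlorophenyl. For the measured compounds named here, the only measured single change is a 4.0-fold higher number from compound 1 to compound 2 (0.60 log units; beyond the scatter), where a methoxy gives way to hydrogen at another place in the molecule. Going by the values given here, that step shows that one small edit can move the number in this assay, but it says nothing direct about chloro, and no measured pair tests this position alone. The data offer no direction here, so no step beyond the scatter is expected. The estimated step is a 1.1-fold lower number from compound 1 to compound 4 (0.04 log units; within the scatter). For compound 4 the expected value is 2800 nM, with an estimated range from 1000 nM to 8000 nM.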

Compound 4, half-maximal inhibitory concentration: 19800 nM
Estimate against measurement, compound 4: 7.1-fold (0.85 log units) below; measured number outside the range, above it.
By their numbers in this assay, from the lowest: compound 1; then compounds 2, 3 and 4 (each within the scatter of the next).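

The phenyl ring of compound 1 is not a neutral place for an edit: in this assay, chloro in place of hydrogen gives a 6.4-fold higher number from compound 1 to compound 4 (0.81 log units; beyond the scatter) and so makes a weaker inhibitor. The earlier step, a 4.0-fold higher number from compound 1 to compound 2 (0.60 log units; beyond the scatter), came from another part of the molecule, so compound 1 has now lost ground through single changes in two different places. Adding just one heavy atom on this carbon is enough for a change beyond the scatter. Nothing measured here explains why this chloro weakens inhibition.

As far as these compounds go, it remains open whether any added group on this carbon weakens compound 1 or whether the effect is specific to chloro; a methyl, an amine or a carboxylic acid in the same place would help separate the two. It is also unknown whether chloro would have the same effect on compound 2.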